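A few compounds are considered here, and "the series" means these few. Any claim that something is new, unique, unknown or untested is made for them only; others in the source may bear on it.

Measured so far:
compound 1, `Cc1ccc(-c2nnc(N3CCN(C(=O)CN4CCN(c5ccccc5)CC4)CC3)nc2-c2ccc(C)cc2)cc1`: in an ADME assay on NIH3T3 cells (Mus musculus) for cytotoxicity, read by MTT assay, with a stated time of 24 h (a lower number here means a stronger inhibitor, a higher number a weaker inhibitor), compound 1 gives > 914000 nM, which is a limit of the assay and not a number.
compound 2, `COc1ccc(-c2nnc(N3CCN(C(=O)CN4CCN(c5ccccc5)CC4)CC3)nc2-c2ccc(OC)cc2)cc1`: in this assay compound 2 gives > 863000 nM, again a limit and not a number.

Going by the values given here, compound 2 therefore stands at the limit of > 863000 nM in this assay, at which 1 of the 2 values shown sits, and the only other value shown sits at the limit of > 914000 nM in this assay, at which 1 of the 2 values shown sits; neither measured compound yields an actual number, so no step between measured compounds can be drawn. Compound 3, `COc1ccc(-c2nnc(N3CCN(C(=O)CN4CCN(c5ccccc5OC)CC4)CC3)nc2-c2ccc(OC)cc2)cc1`, differs from compound 2 by methoxy in place of hydrogen on an aromatic carbon. With both measured values at limits, no shift beyond the scatter is expected from compound 2 to compound 3 in this assay, and the most likely outcome is a further limit rather than a number. Compound 3 is expected to give about 900000 nM in this assay, with a range of 300000 nM to 3000000 nM. The step from compound 2 to compound 3 is accordingly estimated at a step that the limit leaves unreadable from compound 2 to compound 3.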

Compound 3, half-maximal inhibitory concentration: > 821000 nM
Compound 3: no number, only a limit; the forecaster's own chance of this, stated with the estimate: 85%; the middle value does not contradict the limit.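

In this assay compound 3 gives > 821000 nM, a limit and not a number. Compound 2 gives > 863000 nM, again a limit. Going by these compounds alone, no step between compound 2 and compound 3 can be read. The compounds shown leave open what actual number any of them would give in this assay.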